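The source may hold more compounds than are shown below. What is called first, only, known or untested is meant among the compounds shown, and "the series" means these compounds.

In a functional assay on HO8910 cells (Homo sapiens) for cytotoxicity, read by CCK-8 assay, with a stated time of 24 h (on this read-out lower numbers stand for stronger inhibition and higher numbers for weaker inhibition), compound 1 `C/C(=C\c1cc(-c2ccc(F)cc2)co1)C(N)=O` reaches only the assay limit of > 50000 nM, which is not a measured number. Compound 2 `C/C(=C\c1nc(-c2ccccc2)cs1)C(N)=O` gives 3780 nM in this assay. Compound 3 `C/C(=C\c1cc(-c2ccc(C#N)cc2)cs1)C(N)=O` gives 130 nM in this assay, the lowest of the two numbers reported, and compound 2 stands above it by a gap beyond the usual scatter. Compound 4 `C/C(=C\c1cc(-c2ccc(Cl)cc2)cs1)C(N)=O` has not yet been measured in this assay. It differs from compound 3 in one place: chloro in place of cyano on an aromatic carbon. Within the data shown here, no measured pair shows this exchange, so neither its size nor its direction can be read from the data; the change is expected to stay within the usual scatter, if anything toward a slightly weaker result. Compound 4 is therefore expected to give about 250 nM, between 80 nM and 800 nM. The expected step of a 1.9-fold higher number from compound 3 to compound 4 (0.28 log units; within the scatter) would remain within the scatter.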

Compound 4, half-maximal inhibitory concentration: > 50000 nM
Compound 4 gave a limit, no number; the forecaster's own chance of this, stated with the estimate: 3%; middle value at least 200-fold (2.30 log units) away from the limit.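

In this assay chloro in place of cyano on an aromatic carbon, para to a large group, gives an at least 380-fold higher number from compound 3 to compound 4 (2.58 log units; beyond the scatter) and so shows that this single place strongly governs the result. Among the compounds shown, chloro does not keep the low number that cyano gives here. The value of compound 4 is a limit and not a number, so the step marks only a minimum: the limit of > 50000 nM in this assay, at which 2 of the 4 values shown sit.

On these data alone, whether an amine, a carboxylic acid or a methoxy group at this place would keep the number of compound 3 remains open. So does whether a nitrile would have the same effect on the core of compound 2.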